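A few compounds are considered here, and "the series" means these few. Any claim that something is new, unique, unknown or untested is made for them only; others in the source may bear on it.

Going by the values given here, compound 2 `CCCC(=O)OCCOC(=O)c1ccc(C(=O)Nc2ccc3c(c2)C(C)(C)CCC3(C)C)cc1` is the only member with a number in a functional assay on NB-4 cells (Homo sapiens) for inhibition, read by MTT assay, with a stated time of 48 h; on this read-out lower numbers stand for stronger inhibition and higher numbers for weaker inhibition: in this assay compound 2 gives 11000 nM. Compound 1 `C=C(c1ccc(C(=O)NCCCCCCNC(=O)c2ccc(C(=O)Nc3ccc4c(c3)C(C)(C)CCC4(C)C)cc2)cc1)c1cc2c(cc1C)C(C)(C)CCC2(C)C` reaches only a limit of > 1000000 nM in this assay, which is where the limit of > 1000000 nM in this assay, at which 1 of the 2 values shown sits, places it. Compound 3 `CCCC(CCC)C(=O)OCCCOC(=O)c1ccc(C(=O)Nc2ccc3c(c2)C(C)(C)CCC3(C)C)cc1` is not yet measured; it differs from compound 2 by (((1-propylbutyl)carbonyl)oxy)methyl in place of (propylcarbonyl)oxy on a saturated chain carbon, two bonds along the chain from an oxygen next to a carbonyl group. Among the compounds with values here, no measured step of this kind stands, so the change from compound 2 to compound 3 is expected to stay within the usual scatter, the expected step being no change at the digits printed from compound 2 to compound 3 (within the scatter). Compound 3 is therefore estimated at 11000 nM, between 3000 nM and 40000 nM.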

Compound 3, half-maximal inhibitory concentration: > 1000000 nM
Compound 3: no number, only a limit; the forecaster's own chance of this, stated with the estimate: 10%; middle value at least 90-fold (1.95 log units) from the limit.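

In this assay this position proves sensitive, with an at least 90-fold higher number from compound 2 to compound 3 (1.95 log units; beyond the scatter) on this saturated chain carbon. Placing (((1-propylbutyl)carbonyl)oxy)methyl for (propylcarbonyl)oxy is therefore not a neutral change, which the earlier compounds could not show, as no step at this position stood among them. The value of compound 3 is a limit, and compound 1 also gives only a limit:  the limit of > 1000000 nM in this assay, at which 2 of the 3 values shown sit.

Going by these compounds alone, the single step alters the chain and the 1-propylbutyl end together, so their shares cannot be separated. From the compounds shown here alone, whether an amine or a carboxylic acid at this position would give a number in this assay stays open.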